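Swapping the aryl amine substituent in an inactive pair

The source may report more compounds than this note shows. Statements on the series, on what has been measured and on what is new or still open speak of the compounds shown alone.

Compound 1: `FC(F)(F)c1ccc(CSc2nc(N3CCCCC3)c3ccccc3n2)cc1` — in a functional assay on MCF7 cells (Homo sapiens) for cytotoxicity, read by MTT assay, with a stated time of 72 h (a higher number here means a weaker inhibitor, a lower number a stronger inhibitor), compound 1 gives > 50000 nM, a limit of the assay rather than a number.
Compound 2: `O=[N+]([O-])c1cccc(Nc2nc(SCc3ccc(C(F)(F)F)cc3)nc3ccccc23)c1` — in this assay compound 2 gives > 50000 nM, again a limit.

Compound 2 carries (3-nitrophenyl)amino in place of piperidin-1-yl on an aromatic carbon. The step that the two limits leave unreadable from compound 1 to compound 2 cannot be read, since both ends sit at a limit; compound 2 stands at that limit, as the limit of > 50000 nM in this assay, at which 2 of the 2 values shown sit, shows. Compound 3 is `Fc1ccc(Nc2nc(SCc3ccc(C(F)(F)F)cc3)nc3ccccc23)cc1`, and it differs from compound 2 by 4-fluorophenyl in place of 3-nitrophenyl on a nitrogen on an aromatic ring. Going by the values given here, no measured step covers this change, and the single step known, a step that the two limits leave unreadable from compound 1 to compound 2, gives no size to lean on. Nothing in the measured values suggests a gain in potency for compound 3. Compound 3 is expected to show a step that the limit leaves unreadable from compound 2 to compound 3, that is, nothing beyond the scatter. Compound 3 is estimated at 70000 nM, within 15000 nM to 300000 nM, most likely reported only as a limit.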

Compound 3, half-maximal inhibitory concentration: 36300 nM
Beside the measured number, compound 3's estimate is 1.9-fold (0.29 log units) above it; low and high end bracket the measured number.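

Going by these compounds alone, compound 3 is the first compound here to give a real number rather than a limit: in this assay compound 3 gives 36300 nM, so a measurable value can be reached with an aryl group on this nitrogen. Swapping the aryl group gives an at least 1.3-fold lower number from compound 2 to compound 3 (0.13 log units; that floor lies within the scatter), and replacing the piperidine gives an at least 1.3-fold lower number from compound 1 to compound 3 (0.13 log units; that floor lies within the scatter); each is only a floor, so the true steps may be larger, but neither is shown to exceed the scatter. Cytotoxicity therefore remains weak at best, and most of the set still sits at a limit of the assay: the limit of > 50000 nM in this assay, at which 2 of the 3 values shown sit.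

The 3-nitrophenyl and 4-fluorophenyl groups differ in both the substituent and its place on the ring, so the role of each remains unresolved. An unsubstituted phenyl or a 3-fluorophenyl group on the same nitrogen would help separate the two.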